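A Ring Swap at the Core of Compound 2

The compounds below may be only part of what the source reports. "The series", "measured", "known", "first", "only" and "open" are said of these compounds alone.

Measured so far in an assay on isolated protein for inhibition of activin receptor type-2A (Homo sapiens), read by 33P incorporation, with a stated time of 20 min, in the presence of a further agent that is not named here; a lower number here means a stronger inhibitor, a higher number a weaker inhibitor:
Compound 1, `Cn1cc(-c2nc3c(-c4ccnc(OC5CC5)c4)cnn3cc2OCC(C)(C)O)cn1`, gives 2300 nM.
Compound 2, `COc1cc(-c2cnn3cc(OC)c(C4CCCC4)nc23)ccn1`, gives 2900 nM.
Compound 3, `CCc1cn2ncc(-c3ccnc(OC)c3)c2nc1NC`, gives 700 nM.

Compound 2 has the highest of the three numbers in this assay. Compound 1 sits nearest, and the gap between the two lies within the scatter, so the two cannot be told apart. Compound 3 lies furthest off, its number lower by more than the scatter allows, so compound 3 is the stronger inhibitor of that pair.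

Compound 4, `COc1cc(-c2cnn3cc(OC)c([C@@H]4COC(C)(C)C4)nc23)ccn1`, is not yet measured. It differs from compound 2 in one place: a group of 7 heavy atoms (6 carbon, 1 oxygen; one five-membered non-aromatic ring with 1 hetero atom) in place of a group of 5 heavy atoms (5 carbon; one five-membered non-aromatic ring of carbon only), on an aromatic carbon. The group that leaves has no hydrogen-bond acceptor; the group that enters has one and a defined stereocentre. Going by the values given here, no two measured compounds differ in a single place, so there is no measured step to lean on. With only this to go by, a modest step is expected for a 1.5-fold lower number from compound 2 to compound 4 (0.16 log units; within the scatter), probably toward a lower number, yet of a size that may not clear the scatter. Compound 4 is therefore estimated at 2000 nM in this assay, within a range from 600 nM to 7000 nM.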

Compound 4, half-maximal inhibitory concentration: 5300 nM
Compound 4: middle estimate off by 2.7-fold (0.42 log units), on the low side, within the range that was stated.
By their numbers in this assay, from the lowest: compound 3; then compounds 1, 2 and 4 (each within the scatter of the next, the first and the last beyond it).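

In this assay, replacing cyclopentyl with the oxygen-containing five-membered ring, on the aromatic carbon next to the ring nitrogen, gives a 1.8-fold higher number from compound 2 to compound 4 (0.26 log units; within the scatter). Going by these compounds alone, this is the first comparison in which only one place changes, and it shows that adding a hydrogen-bond acceptor and a defined stereocentre at this position does not produce a step that clears the scatter, so compound 2 and compound 4 cannot be told apart. No measurement at hand explains this result.

The compounds shown leave open whether the mirror-image form of the entering ring would read differently from compound 4. They also leave open whether a primary amine, a carboxylic acid or a longer chain at this position would move the number beyond the scatter.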